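Replacing isopentyl with isopropylcarbonyl on the aromatic oxygen

This account rests on a few compounds, and the source may have more. Where it says the series, first, only, none or still open, it means among the compounds named here.

In a functional assay on DLD-1 cells (Homo sapiens) for cytotoxicity, with a stated time of 48 h (a higher number here means a weaker inhibitor, a lower number a stronger inhibitor), compound 3 `CC(C)CCOc1ccc2oc(/C=C/[S+](C)[O-])cc(=O)c2c1` gives 4100 nM as the lowest number shown. Compound 2 `CCCC(=O)Oc1ccc2oc(/C=C/[S+](C)[O-])cc(=O)c2c1` gives 8700 nM as the next number. Compound 1 `CC(=O)Oc1ccc2oc(/C=C/[S+](C)[O-])cc(=O)c2c1` reports > 10000 nM as a limit only. Compound 4 `CC(C)C(=O)Oc1ccc2oc(/C=C/[S+](C)[O-])cc(=O)c2c1` differs from compound 3 by isopropylcarbonyl in place of isopentyl on an oxygen on an aromatic ring with isopropylcarbonyl in place of isopentyl on an oxygen on an aromatic ring. Among the compounds with values here, two measured steps bear on this: a 2.1-fold lower number from compound 2 to compound 3 (0.33 log units; beyond the scatter) and an at least 2.4-fold lower number from compound 1 to compound 3 (0.38 log units; beyond the scatter) with isopentyl arriving in both. Reversing that change, a modest rise is expected in this assay with a higher number for compound 4. Within the data shown here, the expected change is a 2.2-fold higher number from compound 3 to compound 4 (0.34 log units; beyond the scatter) and no larger step is foreseen. Compound 4 is estimated at 9000 nM with 5000 nM to 16000 nM as the expected range.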

Compound 4, half-maximal inhibitory concentration: 9100 nM
Estimate against measurement, compound 4: 1.0-fold (0.00 log units) below, within the range that was stated.
By their numbers in this assay, from the lowest: compound 3; then compounds 2 and 4 (each within the scatter of the next). At a limit, above all of these: compound 1.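

In this assay, the change from isopentyl to isopropylcarbonyl on the aromatic oxygen gives a 2.2-fold higher number from compound 3 to compound 4 (0.35 log units; beyond the scatter), so isopentyl now stands apart from a branched acyl group as well as from a straight one. Isopropyl in place of propyl on the carbonyl carbon gives a 1.0-fold higher number from compound 2 to compound 4 (0.02 log units; within the scatter). Isopropyl in place of methyl on the carbonyl carbon gives an at least 1.0-fold lower number from compound 1 to compound 4 (0.04 log units; that floor lies within the scatter). Compound 1 stands only at a limit: the limit of > 10000 nM in this assay, at which 1 of the 4 values shown sits.

On these data alone, it remains open whether the lower number of compound 3 follows from the isopentyl chain itself or from any alkyl group on that oxygen, such as ethyl or benzyl.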